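Extending the hydroxycarbamoyl chain of a measured series

The compounds below may be only part of what the source reports. "The series", "measured", "known", "first", "only" and "open" are said of these compounds alone.

Measured in a functional assay on MCF7 cells (Homo sapiens) for inhibition, read by MTT assay, with a stated time of 72 h; a lower number here means a stronger inhibitor, a higher number a weaker inhibitor:
- compound 1 `Nc1ncnc2c1c(-c1cnc3[nH]ccc3c1)nn2CCCCCCCCC(=O)NO` gives 24700 nM
- compound 2 `Nc1nc2cc(-c3nn(CCCCC(=O)NO)c4ncnc(N)c34)ccc2o1` gives 14000 nM
- compound 3 `Nc1nc2cc(-c3nn(CCCCCC(=O)NO)c4ncnc(N)c34)ccc2o1` gives 12400 nM

Compound 3 stands within the scatter of both compound 2 and compound 1, so these three cannot be ranked. Compound 4 `Nc1nc2cc(-c3nn(CCCCCCCCC(=O)NO)c4ncnc(N)c34)ccc2o1` has not yet been measured. It carries 3-(hydroxycarbamoyl)propyl in place of hydroxycarbamoyl on a saturated chain carbon, five bonds along the chain from an aromatic nitrogen. Among the compounds with values here, the one measured step on this chain is a 1.1-fold lower number from compound 2 to compound 3 (0.05 log units; within the scatter) for (hydroxycarbamoyl)methyl in place of hydroxycarbamoyl, and a single step of that size sets no trend. On the chain that compound 4 carries, but with a different group on the core, compound 1 gives 24700 nM and still lies within the scatter of compound 3. No measurement shows this longer chain on the core of compound 3, so no change beyond the scatter is expected. The expected step is a 1.1-fold lower number from compound 3 to compound 4 (0.05 log units; within the scatter) in this assay and leans only slightly towards a lower number. For compound 4 the estimate is 11000 nM with an expected range from 4000 nM to 30000 nM in this assay as the assay reads it.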

Compound 4, half-maximal inhibitory concentration: 42100 nM
Compound 4: the middle estimate sits 3.8-fold (0.58 log units) below what was measured; measured number outside the range, above it.
By their numbers in this assay, from the lowest: compounds 3, 2, 1 and 4 (each within the scatter of the next, the first and the last beyond it).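

In this assay, within the data shown here, this chain position proves sensitive to length, which the earlier compounds did not show: the only earlier step on this chain, a 1.1-fold lower number from compound 2 to compound 3 (0.05 log units; within the scatter), gave no readable change. Placing 3-(hydroxycarbamoyl)propyl in place of hydroxycarbamoyl gives a 3.4-fold higher number from compound 3 to compound 4 (0.53 log units; beyond the scatter), and the wider change to 4-(hydroxycarbamoyl)butyl gives a 3.0-fold higher number from compound 2 to compound 4 (0.48 log units; beyond the scatter), so the longest chain reads as weaker than both shorter chains on the shared core. With this longest chain, the two groups on the aromatic carbon cannot be told apart, at a 1.7-fold higher number from compound 1 to compound 4 (0.23 log units; within the scatter).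

A longer chain than that of compound 4, or a carboxylic acid in place of the hydroxycarbamoyl end, does not appear among the compounds shown, so whether the number keeps rising and what that end contributes stay open. Nothing available explains the loss seen with the longest chain.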